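The source may hold more compounds than are shown below. What is called first, only, known or untested is meant among the compounds shown, and "the series" means these compounds.

Three compounds share one core and differ only in the group on the sulfonyl sulfur. In an ADME assay on Huh-7 cells (Homo sapiens) for cytotoxicity, read by MTT assay (a lower number here means that less compound is tolerated, a higher number that more compound is tolerated), compound 1 `CS(=O)(=O)N(CCCCCCN1C[C@H](O)[C@@H](O)[C@H](O)[C@H]1CO)C1CCCCC1` reaches only a limit, > 500000 nM. Compound 2 `O=S(=O)(c1ccccc1)N(CCCCCCN1C[C@H](O)[C@@H](O)[C@H](O)[C@H]1CO)C1CCCCC1` gives 280000 nM in this assay. Compound 3 `CC(C)(C)S(=O)(=O)N(CCCCCCN1C[C@H](O)[C@@H](O)[C@H](O)[C@H]1CO)C1CCCCC1` likewise reaches only the limit, > 500000 nM. The steps are an at least 1.7-fold lower number from compound 1 to compound 2 (0.25 log units; that floor lies within the scatter), a step that the two limits leave unreadable from compound 1 to compound 3 and an at least 1.7-fold higher number from compound 2 to compound 3 (0.25 log units; that floor lies within the scatter); two of them rest on (the limit of > 500000 nM in this assay, at which 2 of the 3 values shown sit), so none of them can be read as a real shift. Compound 3 thus stands at the limit, where one further value also sits, and no number is known for it. Compound 4 `CC(C)(C)NC(=O)N(CCCCCCN1C[C@H](O)[C@@H](O)[C@H](O)[C@H]1CO)C1CCCCC1` differs from it by (tert-butyl)carbamoyl in place of (tert-butyl)sulfonyl on an amine nitrogen. Among the measured compounds shown here, no measured step touches this kind of change: all three concern the group on the sulfonyl sulfur, and none of them left the scatter. For this assay no step beyond the scatter is therefore expected. Compound 4 is expected to give 500000 nM, with a range from 200000 nM to 1000000 nM. This expectation corresponds to a number no higher from compound 3 to compound 4 (the limit leaves the size open).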

Compound 4, half-maximal cytotoxic concentration: > 500000 nM
Compound 4: no number, only a limit (the forecaster's own chance of this, stated with the estimate: 60%); the middle value sits exactly at the limit.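

Among the compounds shown here, compound 4 carries the first group on this amine nitrogen that is not a sulfonyl group, and with (tert-butyl)carbamoyl in place of (tert-butyl)sulfonyl it still reaches only a limit in this assay. The steps to compound 4 from compound 3 and from compound 1 cannot be read: the limit of > 500000 nM in this assay, at which 3 of the 4 values shown sit.
For the compounds shown here, the one step that can be read is an at least 1.7-fold higher number from compound 2 to compound 4 (0.25 log units; that floor lies within the scatter), so even this change of group shows no shift beyond the scatter.

Going by these compounds, how far compound 3 and compound 4 lie apart stays open, as neither has a number. On these data alone, it is also open whether phenylcarbamoyl or an acetyl group on this nitrogen would give a number rather than a limit, as the phenylsulfonyl group of compound 2 does.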